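Widening the amide substituent on a shared triazolopyrimidine core

A few compounds are considered here, and "the series" means these few. Any claim that something is new, unique, unknown or untested is made for them only; others in the source may bear on it.

Compound 3 `O=C(Nc1nc(-c2ccccc2)nc2c1nnn2Cc1ccccc1)c1ccoc1` gives the lowest number of the three compounds measured in an assay (strain Wistar) for displacement of a labelled ligand from adenosine receptor A1 (Rattus norvegicus), read by scintillation counting; a lower number here means a stronger inhibitor, a higher number a weaker inhibitor: compound 3 gives 10 nM. Its nearest neighbour is compound 1 `O=C(Nc1nc(-c2ccccc2)nc2c1nnn2Cc1ccccc1)C1CCCCC1`, which in this assay gives 12 nM; the step of a 1.2-fold lower number from compound 1 to compound 3 (0.08 log units; within the scatter) is within the scatter. The furthest is compound 2 `COc1ccc(Cl)cc1C(=O)Nc1nc(-c2ccccc2)nc2c1nnn2Cc1ccccc1`, which in this assay gives 7150 nM; the step of a 720-fold lower number from compound 2 to compound 3 (2.85 log units; beyond the scatter) is beyond the scatter, as is a 600-fold higher number from compound 1 to compound 2 (2.78 log units; beyond the scatter).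

Compound 4 `O=C(Nc1nc(-c2ccccc2)nc2c1nnn2Cc1ccccc1)c1cccc(C(F)(F)F)c1` carries the change (3-(trifluoromethyl)phenyl in place of furan-3-yl on a carbonyl carbon). The measured steps that bear on it are the two replacements at the same carbonyl carbon: the move to a substituted six-membered aromatic ring of carbon only, a 600-fold higher number from compound 1 to compound 2 (2.78 log units; beyond the scatter), was large, whereas the move between two smaller groups, a 1.2-fold lower number from compound 1 to compound 3 (0.08 log units; within the scatter), was within the scatter. Compound 4 enters a six-membered aromatic ring of carbon only bearing a trifluoromethyl group, a larger group than furan-3-yl, so he expects the number to rise, though less steeply than for compound 2, whose substitution pattern differs. For compound 4 in this assay he therefore estimates 150 nM, with a range from 15 nM to 2000 nM. This estimate corresponds to an expected step of a 15-fold higher number from compound 3 to compound 4 (1.18 log units; beyond the scatter).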

Compound 4, inhibition constant: 163 nM
Compound 4: the middle estimate sits 1.1-fold (0.04 log units) below what was measured; measured number inside the range.
By their numbers in this assay, from the lowest: compounds 3 and 1 (each within the scatter of the next); then compound 4; then compound 2.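

Compound 4 shows that a six-membered aromatic ring of carbon only on this carbonyl carbon need not cost as much as compound 2 suggested: in this assay there is a 44-fold lower number from compound 2 to compound 4 (1.64 log units; beyond the scatter), even though both compounds carry such a ring. The ring alone therefore does not set the number, since 3-(trifluoromethyl)phenyl and 5-chloro-2-methoxyphenyl, which differ in what the ring carries, lie far apart. The new group still does not match the smaller groups, which could not be told apart from each other, with a 16-fold higher number from compound 3 to compound 4 (1.21 log units; beyond the scatter) and a 14-fold higher number from compound 1 to compound 4 (1.13 log units; beyond the scatter), so this position separates groups that the first three compounds alone placed only at two extremes.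

Nothing available here bears on the cause of these differences. Open, on these data alone, is how much of the gap to furan-3-yl and cyclohexyl belongs to the six-membered aromatic ring and how much to the trifluoromethyl group, which an unsubstituted phenyl ring on the same carbonyl carbon would help to separate, and how an amine or a carboxylic acid on that ring would read in this assay.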